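Working notes on a carboxymethyl-bearing series: compound 3 to compound 4

The source may hold more compounds than are shown below. What is called first, only, known or untested is meant among the compounds shown, and "the series" means these compounds.

Measured so far:
- compound 1 `Nc1nc(-c2ccc(Cl)cc2)c(CC(=O)O)s1`: in an in vitro functional assay on HEK285-7 cells for antagonist activity at prostaglandin D2 receptor 2 (Homo sapiens), read by BRET and beta-arrestin recruitment (on this read-out lower numbers stand for stronger inhibition and higher numbers for weaker inhibition), compound 1 gives > 100000 nM, a limit of the assay, not a number.
- compound 2 `O=C(O)Cc1sc(C(c2ccc(F)cc2)c2ccc(F)cc2)nc1-c1ccccc1`: in this assay compound 2 gives 240 nM.
- compound 3 `O=C(O)Cc1sc(C(c2ccccc2)c2ccccc2)nc1-c1ccc(C(F)(F)F)cc1`: in this assay compound 3 gives > 100000 nM, again a limit and not a number.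

Compound 3 therefore stands at the limit of > 100000 nM in this assay, at which 2 of the 3 values shown sit, so no measured number of its own is known, only that it falls beyond the range the assay reports. Compound 4 `O=C(O)Cc1sc(C(c2ccccc2)c2ccccc2)nc1-c1ccc(F)c(F)c1` has not been measured. From compound 3 to compound 4 the change is 3,4-difluorophenyl in place of 4-(trifluoromethyl)phenyl on an aromatic carbon. Among the compounds with values here, no step between two measured compounds is available that resembles this change, so the size of the step cannot be read from the series; only compound 2 shows that a number inside the reported range is reachable. A step toward stronger inhibition is expected, but with wide uncertainty, since compound 3 offers only a limit as the starting point. For compound 4 the expected step in this assay is an at least 12-fold lower number from compound 3 to compound 4 (1.09 log units; beyond the scatter). Compound 4 is thus estimated at 8000 nM, within a range from 800 nM to 100000 nM.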

Compound 4, half-maximal inhibitory concentration: 43 nM
Beside the measured number, compound 4's estimate is 190-fold (2.27 log units) above it; the whole stated range lies above it.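

At this aromatic carbon, next to the ring nitrogen and next to the ring atom that bears a carboxymethyl group, the choice of substituted phenyl alone moves the read-out in this assay from a limit into the measured range, with an at least 2300-fold lower number from compound 3 to compound 4 (3.36 log units; beyond the scatter). The earlier compounds shown here gave no pair differing in one place, so they could not tie any difference to this position. The step remains a bound and not a size, because compound 3 offers a limit and not a number: the limit of > 100000 nM in this assay, at which 2 of the 4 values shown sit.

The compounds shown leave open whether a single fluorine, a chlorine or a methoxy group on this phenyl would serve as 3,4-difluorophenyl does. They also leave open whether the step holds when a longer carboxylic acid chain replaces the carboxymethyl group.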